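The source may report more compounds than this note shows. Statements on the series, on what has been measured and on what is new or still open speak of the compounds shown alone.

In an assay on isolated protein for inhibition of retinal dehydrogenase 2 (Homo sapiens) (a lower number here means a stronger inhibitor, a higher number a weaker inhibitor), compound 3 `CCC(Sc1nc2c(cnn2C)c(=O)n1-c1ccccc1)c1ccccc1` gives 179 nM. Among the three compounds measured so far this is the second highest number. Going by the values given here, compound 1 `CC(C)C(Sc1nc2c(cnn2C)c(=O)n1-c1ccccc1)c1ccccc1` gives 300 nM; the one step between these two, a 1.7-fold lower number from compound 1 to compound 3 (0.22 log units; within the scatter), lies within the scatter. Among the compounds with values here, compound 2 `CC(Sc1nc2nn(CC3COC3)cc2c(=O)n1-c1ccccc1)c1ccccc1` gives 80 nM, a lower number beyond the scatter from compound 3, but compound 2 differs from compound 3 in more than one place, so only the two values themselves are available and no single step is counted.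

Compound 4 `CC(Sc1nc2c(cnn2C)c(=O)n1-c1ccccc1)c1cncnc1` is not yet measured. It differs from compound 3 in one place: 1-(pyrimidin-5-yl)ethyl in place of 1-phenylpropyl on a sulfur. Within the data shown here, of the measured steps only the one from compound 1 to compound 3 bears on this change, and only in part: it also trims the saturated chain on the sulfur and stays within the scatter. Among the measured compounds shown here, no measured pair isolates the exchange of the six-membered aromatic ring of carbon only for the six-membered aromatic ring with 2 hetero atoms, so the data do not tell where that part of the change leads. The expectation for compound 4 is therefore a step of a 1.4-fold higher number from compound 3 to compound 4 (0.15 log units; within the scatter), with a wide range to cover the unknown ring exchange. Compound 4 is estimated at 250 nM, between 80 nM and 800 nM.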

Compound 4, half-maximal inhibitory concentration: 380 nM
Beside the measured number, compound 4's estimate is 1.5-fold (0.18 log units) below it; measured number inside the range.
By their numbers in this assay, from the lowest: compound 2; then compounds 3, 1 and 4 (each within the scatter of the next, the first and the last beyond it).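

In this assay, going by these compounds alone, the exchange of 1-phenylpropyl for 1-(pyrimidin-5-yl)ethyl on a sulfur gives the first single-place change to pass the scatter, though only modestly: a 2.1-fold higher number from compound 3 to compound 4 (0.33 log units; beyond the scatter). The only earlier step, a 1.7-fold lower number from compound 1 to compound 3 (0.22 log units; within the scatter), touched just the saturated chain and stayed within the scatter, whereas the new step also replaces the six-membered aromatic ring of carbon only with a six-membered aromatic ring with 2 hetero atoms, so this position on the sulfur is now shown to respond to a change that includes the aromatic ring, while still giving a value in the same range as the other compounds. No measurement on hand accounts for the step.

The step joins a ring exchange to a shorter chain, so the share of each remains unresolved, and 1-(pyrimidin-5-yl)propyl or 1-phenylethyl on the core of compound 3 would separate them. From the compounds shown here alone, whether the hetero atoms themselves matter also remains open, and a 1-(pyridin-3-yl)ethyl group, with a single ring nitrogen, would bear on that question.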